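Working notes: step from compound 3 to compound 4

This account rests on a few compounds, and the source may have more. Where it says the series, first, only, none or still open, it means among the compounds named here.

Measured compounds:
Compound 1, `Cc1cc(SC(C)(C)C)c(S(C)(=O)=O)cc1C(=O)N=C(N)N`, gives 22 nM in a functional assay for inhibition of sodium/hydrogen exchanger (Oryctolagus cuniculus); a lower number here means a stronger inhibitor, a higher number a weaker inhibitor.
Compound 2, `Cc1cc(Sc2ccccc2)c(S(C)(=O)=O)cc1C(=O)N=C(N)N`, gives 14 nM in this assay.
Compound 3, `Cc1cc(Nc2ncccn2)c(S(C)(=O)=O)cc1C(=O)N=C(N)N`, gives 8.3 nM in this assay.

Compound 3 holds the lowest of the three numbers. One measured step ends at it and stays within the scatter: a 1.7-fold lower number from compound 2 to compound 3 (0.23 log units; within the scatter). The other measured step ending at it goes beyond the scatter: a 2.7-fold lower number from compound 1 to compound 3 (0.42 log units; beyond the scatter). Compound 3 can therefore not be called stronger than compound 2 on these numbers.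

Compound 4, `Cc1cc(C(F)(F)F)c(S(C)(=O)=O)cc1C(=O)N=C(N)N`, is the next candidate. Compared with compound 3 the change is trifluoromethyl in place of (pyrimidin-2-yl)amino on an aromatic carbon.

Within the data shown here, two measured steps touch this position: a 2.7-fold lower number from compound 1 to compound 3 (0.42 log units; beyond the scatter) and a 1.7-fold lower number from compound 2 to compound 3 (0.23 log units; within the scatter). Both ran toward the (pyrimidin-2-yl)amino group and both lowered the number, one modestly, one within the scatter. Among the measured compounds shown here, compound 4 runs the other way, away from that group, but toward a trifluoromethyl, which no measured compound carries. A move back toward the range of compound 1 and compound 2 is therefore expected, of modest size at most: a 3.0-fold higher number from compound 3 to compound 4 (0.48 log units; beyond the scatter).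

For compound 4 the expected value in this assay is 25 nM, with a range from 8 nM to 80 nM.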

Compound 4, half-maximal inhibitory concentration: 37 nM
Compound 4: the middle estimate sits 1.5-fold (0.17 log units) below what was measured, within the range that was stated.
By their numbers in this assay, from the lowest: compounds 3, 2, 1 and 4 (each within the scatter of the next, the first and the last beyond it).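

Compound 4 shows that this position, ortho to a methylsulfonyl group, can hold a group with no ring and no hydrogen-bond donors or acceptors: in this assay compound 4 gives 37 nM, but this comes with a 4.5-fold higher number from compound 3 to compound 4 (0.65 log units; beyond the scatter) and a 2.6-fold higher number from compound 2 to compound 4 (0.42 log units; beyond the scatter), whereas a 1.7-fold higher number from compound 1 to compound 4 (0.23 log units; within the scatter) leaves trifluoromethyl unresolved from (tert-butyl)sulfanyl. The two groups that carry a ring, (pyrimidin-2-yl)amino and phenylsulfanyl, therefore both stand apart from trifluoromethyl, though ring content alone does not sort the series: compound 1, with no ring, goes against that reading, as a 1.6-fold lower number from compound 1 to compound 2 (0.20 log units; within the scatter) does not separate it from the phenylsulfanyl compound. No supporting data bear on why these differences arise.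

The compounds shown leave open whether the gap to compound 3 follows the aromatic ring or the linking nitrogen, which a plain amino group, a phenylamino group or a directly attached phenyl at this position would help to separate. Also open, going by these compounds, is how small groups such as methyl, nitrile or a carboxylic acid would sit relative to trifluoromethyl on the same core.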